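Swapping tert-Butyl for Ethoxy on a Z-Stilbene

This account rests on a few compounds, and the source may have more. Where it says the series, first, only, none or still open, it means among the compounds named here.

Compound 1, `COc1cc(/C=C\c2ccc(C(C)(C)C)cc2)cc(OC)c1OC`, is the only one of the two measured compounds with a number rather than a limit. In a functional assay on HT-29 cells (Homo sapiens) for cytotoxicity (on this read-out lower numbers stand for an effect already at smaller amounts and higher numbers for an effect only at larger amounts of compound), compound 1 gives 8.8 uM. Compound 2, `COc1cc(/C=C/c2ccc(C(C)(C)C)cc2)cc(OC)c1OC`, has the same atoms and bonds as compound 1 and differs only in the drawn configuration of the double bond. In this assay compound 2 reaches only the limit of > 25 uM, not a number. Going by the values given here, the step of an at least 2.8-fold higher number from compound 1 to compound 2 (0.45 log units; beyond the scatter) is thus the single measured change, and it concerns geometry alone (the fact that compounds 1 and 2 differ only in the configuration as drawn), with one of the two values sitting at the limit (the limit of > 25 uM in this assay, at which 1 of the 2 values shown sits).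

Compound 3, `CCOc1ccc(/C=C\c2cc(OC)c(OC)c(OC)c2)cc1`, keeps the Z-drawn double bond of compound 1 and alters one substituent: ethoxy in place of tert-butyl on an aromatic carbon. Among the compounds with values here, no measured step tests a change of this kind, so the step from compound 1 to compound 2 offers no direct guidance, and the expected step of a 1.5-fold lower number from compound 1 to compound 3 (0.17 log units; within the scatter) is estimated to stay within the usual scatter. Compound 3 is therefore expected to give 6 uM in this assay, with a range from 1.5 uM to 25 uM.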

Compound 3, concentration for half-maximal effect: 1.8 uM
The estimate for compound 3 lay 3.3-fold (0.52 log units) above the measured number, and the stated range covers the measured number.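

Up to this point only the geometry of the double bond had changed while tert-butyl stayed in place, so nothing yet showed whether the group on this aromatic carbon, para to a large group, matters in this assay. It does matter: with the Z-drawn double bond kept, ethoxy in place of tert-butyl gives a 4.9-fold lower number from compound 1 to compound 3 (0.69 log units; beyond the scatter) and so tert-butyl, a group of carbon alone, is not required here, since a group with an oxygen and one hydrogen-bond acceptor gives a lower number. What lies behind this step remains unexplained, as nothing measured on these compounds speaks to why the two groups differ.

The compounds shown leave open which feature of ethoxy goes with the lower number, since the swap alters the heavy atoms, the oxygen and the acceptor count all at once. They also leave open how a longer chain such as butoxy, or an amine, would behave at this place, and whether the E-drawn double bond would raise the number with ethoxy as it does with tert-butyl.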